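Replacing a Nitrophenyl Group in a Cytotoxicity Series

The compounds below may be only part of what the source reports. "The series", "measured", "known", "first", "only" and "open" are said of these compounds alone.

Three compounds sharing a five-membered non-aromatic ring with two nitrogens have been tested in a functional assay on IMR-32 cells (Homo sapiens) for cytotoxicity, read by sulforhodamine B assay, with a stated time of 48 h; on this read-out higher numbers stand for weaker inhibition and lower numbers for stronger inhibition. Compound 1 `COc1cc(OC)c(C2CC(c3ccco3)=NN2C(C)=O)cc1OC` gives 7760 nM in this assay. Compound 2 `CC(=O)N1N=C(c2ccco2)CC1c1cccc(Cl)c1Cl` gives 62200 nM in this assay. Compound 3 `O=CCN1N=C(c2ccc3ccccc3c2)CC1c1ccccc1[N+](=O)[O-]` gives 3360 nM in this assay, the lowest number of the three: compound 1 stands a little higher and compound 2 far higher, both gaps beyond the usual scatter, so compound 3 is the strongest inhibitor among them.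

Compound 4 `O=CCN1N=C(c2ccc3ccccc3c2)CC1c1cccc(Br)c1` has not yet been measured. It differs from compound 3 in one place: 3-bromophenyl in place of 2-nitrophenyl on a saturated ring carbon. Among the measured compounds shown here, no pair of measured compounds differing in exactly one place is available, so no step of this kind has been observed. The formylmethyl group and the naphthyl group of compound 3 are kept, and the change touches only the aryl group on the saturated ring carbon. A modest step toward a higher number is expected, not far beyond the scatter. Compound 4 is therefore estimated at 6000 nM, with a range from 1500 nM to 25000 nM, which corresponds to an expected step of a 1.8-fold higher number from compound 3 to compound 4 (0.25 log units; within the scatter).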

Compound 4, half-maximal inhibitory concentration: 9870 nM
Estimate against measurement, compound 4: 1.6-fold (0.22 log units) below, and the stated range covers the measured number.
By their numbers in this assay, from the lowest: compound 3; then compounds 1 and 4 (each within the scatter of the next); then compound 2.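

In this assay, among the compounds shown here, compounds 3 and 4 form the first pair that differ in only one place, and so give the first direct reading for the aryl group on the saturated ring carbon: 3-bromophenyl in place of 2-nitrophenyl gives a 2.9-fold higher number from compound 3 to compound 4 (0.47 log units; beyond the scatter). With the formylmethyl group and the naphthyl group held constant, this shows that the position is not indifferent to the aryl group it carries, although the loss on this exchange is modest and compound 4 keeps measurable activity. The exchange alters both the substituent and its place on the phenyl ring, so this single step cannot separate the two changes, and no measured property is available to explain the difference.

The compounds shown leave open how a plain phenyl group, or a phenyl group carrying an amine or a carboxylic acid, would behave on this saturated ring carbon. They also leave open whether the same exchange would give a step of similar size with a longer chain in place of the formylmethyl group.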